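The source may report more compounds than this note shows. Statements on the series, on what has been measured and on what is new or still open speak of the compounds shown alone.

Three compounds share one core, carried in each case by a group on the amine nitrogen of the ring. Compound 1 `Nc1scc(CN2CCN(c3ccc(Cl)c(C(F)(F)F)c3)CC2)c1C(=O)c1ccc(Cl)cc1`, compound 2 `Nc1scc(CN2CCN(c3cccc(F)c3)CC2)c1C(=O)c1cccc(C(F)(F)F)c1` and compound 3 `Nc1scc(CN2CCN(c3c(F)cccc3F)CC2)c1C(=O)c1cccc(C(F)(F)F)c1` were tested in a functional assay on CHO cells with adenosine receptor A1 (Homo sapiens) as the target, read by cAMP accumulation and immunoassay, with a stated time of 6 min, tested at 0.1 uM; a lower number here means a stronger effect, a higher number a weaker effect of the compound at the concentration tested. Compound 1 gives -12%, compound 2 gives -12% and compound 3 gives 1.3%; compound 1 is therefore level with compound 2, and together they sit lowest of the three. Within the data shown here, the only measured step that alters the group on that ring nitrogen is a number 13.3 percentage points higher from compound 2 to compound 3 (beyond the scatter). Compound 4 `Nc1scc(CN2CCN(c3ccc(F)c(F)c3)CC2)c1C(=O)c1ccc(Cl)cc1` changes the same place on compound 1: 3,4-difluorophenyl in place of 4-chloro-3-(trifluoromethyl)phenyl on an amine nitrogen in a ring. Because a number 13.3 percentage points higher from compound 2 to compound 3 (beyond the scatter) was only modest, compound 4 is expected to move little, estimated as a number 7 percentage points higher from compound 1 to compound 4 (within the scatter). Compound 4 is estimated at -5%, within -20% to 10%.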

Compound 4, a percentage reported as activity, at one concentration (the size of the read-out at that concentration, not a potency): -34%
For compound 4 the middle estimate is 29 percentage points above the measured one, and the stated range ends above it.
By their numbers in this assay, from the lowest: compound 4; then compounds 1 and 2 (each within the scatter of the next); then compound 3.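

In this assay, 3,4-difluorophenyl in place of 4-chloro-3-(trifluoromethyl)phenyl gives a number 22 percentage points lower from compound 1 to compound 4 (beyond the scatter) and so a stronger effect at the concentration tested. The group on this ring nitrogen can therefore move the number down as well as up, whereas the earlier change gave a number 13.3 percentage points higher from compound 2 to compound 3 (beyond the scatter). Nothing available here explains this shift. From the compounds shown here alone, it remains open whether the same swap would act alike on compound 2, which has a different group on the carbonyl. Going by these compounds, the effect of a pyridine ring or a benzyl group at this nitrogen also remains open.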